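A few compounds are considered here, and "the series" means these few. Any claim that something is new, unique, unknown or untested is made for them only; others in the source may bear on it.

Compound 1, `CN1C[C@H](C(=O)Nc2ccc(C(F)(F)F)cc2)[C@@H](c2ccc(/C=C/C(=O)Nc3ccccc3N)cc2)C1`, gives 23 mL/min/kg in an in vitro ADME assay on microsomes from liver (Mus musculus) for pharmacokinetics, read by LC-MS, with a stated time of 10 min, tested at 1 uM; on this read-out lower numbers stand for slow clearance and higher numbers for fast clearance.
Compound 2, `CN1C[C@H](C(=O)Nc2ccc(Br)cc2)[C@@H](c2ccc(/C=C/C(=O)Nc3ccccc3N)cc2)C1`, gives 16 mL/min/kg in this assay.
Compound 3, `CN1C[C@H](C(=O)Nc2ccccc2F)[C@@H](c2ccc(/C=C/C(=O)Nc3ccccc3N)cc2)C1`, gives 67 mL/min/kg in this assay.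

Among these three, compound 3 shows the highest number: the step of a 2.9-fold higher number from compound 1 to compound 3 (0.46 log units; beyond the scatter) and the step of a 4.2-fold higher number from compound 2 to compound 3 (0.62 log units; beyond the scatter) both run upward and both lie beyond the scatter, while a 1.4-fold lower number from compound 1 to compound 2 (0.16 log units; within the scatter) stays within it. Compound 4, `CN1C[C@H](C(=O)Nc2ccc(Cl)c(Cl)c2)[C@@H](c2ccc(/C=C/C(=O)Nc3ccccc3N)cc2)C1`, has not yet been measured in this assay. It differs from compound 3 in one place: 3,4-dichlorophenyl in place of 2-fluorophenyl on an amide-type nitrogen. The two steps that bear on this change are the ones in which the group on the amide-type nitrogen was exchanged, a 2.9-fold higher number from compound 1 to compound 3 (0.46 log units; beyond the scatter) and a 4.2-fold higher number from compound 2 to compound 3 (0.62 log units; beyond the scatter); each moved the number upward when 4-(trifluoromethyl)phenyl or 4-bromophenyl gave way to 2-fluorophenyl. Replacing 2-fluorophenyl with 3,4-dichlorophenyl, as in compound 4, is expected to move the number back downward, a 2.7-fold lower number from compound 3 to compound 4 (0.43 log units; beyond the scatter). Compound 4 is estimated at 25 mL/min/kg, with a likely range from 10 mL/min/kg to 55 mL/min/kg.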

Compound 4, clearance: 36 mL/min/kg
Compound 4: the middle estimate sits 1.4-fold (0.16 log units) below what was measured; the range from low to high includes it.
By their numbers in this assay, from the lowest: compounds 2, 1, 4 and 3 (each within the scatter of the next, the first and the last beyond it).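

In this assay, swapping groups on the amide-type nitrogen gives a 1.9-fold lower number from compound 3 to compound 4 (0.27 log units; within the scatter) and a 1.6-fold higher number from compound 1 to compound 4 (0.19 log units; within the scatter), so 3,4-dichlorophenyl cannot be told apart from either 2-fluorophenyl or 4-(trifluoromethyl)phenyl, even though those two groups differ beyond the scatter from each other. Only a 2.3-fold higher number from compound 2 to compound 4 (0.35 log units; beyond the scatter) clearly separates the new group from another, so the earlier split between 2-fluorophenyl and the other two groups now has a compound lying in the gap rather than on either side. Nothing available here explains why clearance shifts with the group at this position.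

Every group shown on this nitrogen is a phenyl ring carrying fluorine, chlorine, bromine or trifluoromethyl, so it remains open how a methoxyphenyl, a pyridine ring or a cyclohexyl group would read. Going by these compounds, it also remains open whether these differences would hold if the shared core were changed elsewhere.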